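Halogen pattern on the carbamate aryl group and PANC-1 inhibition

The compounds below may be only part of what the source reports. "The series", "measured", "known", "first", "only" and "open" are said of these compounds alone.

Three compounds share one core and differ only in the aromatic group attached to the amide-type nitrogen of a carbamate. In a functional assay on PANC-1 cells (Homo sapiens) for inhibition, read by MTT assay, with a stated time of 24 h, tested at 10 uM (a higher number here means more inhibition at the concentration tested (going by the name of the read-out), a lower number less inhibition), compound 1 `COc1cccc(NC(=O)Oc2cc(=O)n(CCCO)c3c2CC(CC=C(C)C)C(C)(C)C3)c1` gives 16.2%. Compound 2 `CC(C)=CCC1Cc2c(OC(=O)Nc3ccc(F)cc3)cc(=O)n(CCCO)c2CC1(C)C` gives 71.2%, and compound 3 `CC(C)=CCC1Cc2c(OC(=O)Nc3ccccc3F)cc(=O)n(CCCO)c2CC1(C)C` gives 52.3%. Compound 3 thus stands second highest of the three numbers: the step of a number 18.9 percentage points lower from compound 2 to compound 3 (beyond the scatter) is modest, while the step of a number 36.1 percentage points higher from compound 1 to compound 3 (beyond the scatter) is large, as is a number 55 percentage points higher from compound 1 to compound 2 (beyond the scatter).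

Compound 4 `CC(C)=CCC1Cc2c(OC(=O)Nc3ccc(Cl)c(Cl)c3)cc(=O)n(CCCO)c2CC1(C)C` is not yet measured. Compared with compound 3 the change is 3,4-dichlorophenyl in place of 2-fluorophenyl on an amide-type nitrogen. For the measured compounds named here, no measured pair swaps a fluorine for two chlorines, so the closest guide is the comparison of the two fluorophenyl compounds: compound 2, with 4-fluorophenyl, sits above compound 3, with 2-fluorophenyl, by a modest amount in this assay. A further guide is that both fluorophenyl compounds lie far above the 3-methoxyphenyl compound 1. On this basis compound 4 is expected to move upward by a number 12.7 percentage points higher from compound 3 to compound 4 (beyond the scatter), a modest step. The estimated value for compound 4 is 65%, within a range from 40% to 88%.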

Compound 4, a percentage reported as inhibition, at one concentration (the size of the read-out at that concentration, not a potency): 61.4%
The estimate for compound 4 lay 3.6 percentage points above the measured number; measured number inside the range.
By their numbers in this assay, from the lowest: compound 1; then compounds 3, 4 and 2 (each within the scatter of the next, the first and the last beyond it).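

In this assay, replacing a single fluorine with two chlorines on the aryl group at this amide-type nitrogen gives no separable change: the results are a number 9.1 percentage points higher from compound 3 to compound 4 (within the scatter) and a number 9.8 percentage points lower from compound 2 to compound 4 (within the scatter). The earlier compounds had shown only that two fluorophenyl groups could be told apart from each other and from 3-methoxyphenyl; 3,4-dichlorophenyl now falls within the scatter of both, even though it differs from them in the halogen and in the number of halogen atoms, while the contrast with 3-methoxyphenyl remains clear, at a number 45.2 percentage points higher from compound 1 to compound 4 (beyond the scatter). Among these four compounds, then, all three halogen-bearing aryl groups stand well clear of the methoxy-bearing one, with no compound going against that pattern, but nothing available explains why this is so.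

The compounds shown leave open whether the halogens are needed at all, which a plain phenyl group would help to test. They also leave open how a phenyl group carrying an amine or a carboxylic acid at this nitrogen would read out, and how any of these groups would behave across a range of concentrations rather than at a single one.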